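The source may report more compounds than this note shows. Statements on the series, on what has been measured and on what is new or still open speak of the compounds shown alone.

Measured so far:
- compound 1, `O=C(/C(=N/O)Nc1ccc(F)c(Br)c1)C1CCN(C(=O)NCc2ccccc2)CC1`: 43 nM
- compound 2, `O=C(Nc1ccccc1)[C@H]1CC[C@H](C(=O)/C(=N/O)Nc2ccc(F)c(Br)c2)CC1`: 150 nM

Of the compounds shown here, two share a core and have been tested in an assay for inhibition of Indoleamine 2,3-dioxygenase 1 (Homo sapiens), with a stated time of 1 h; on this read-out higher numbers stand for weaker inhibition and lower numbers for stronger inhibition. Compound 1 gives the lower of the two numbers, 43 nM, and compound 2 the higher, 150 nM; the gap between them lies beyond the usual scatter of repeated measurements, so compound 1 is the stronger inhibitor of the pair as measured.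

Compound 3, `NS(=O)(=O)N1CCC(C(=O)/C(=N/O)Nc2ccc(F)c(Br)c2)CC1`, has not yet been measured. It keeps the core of compound 1 and differs in one place: sulfamoyl in place of benzylcarbamoyl on an amine nitrogen in a ring. A large group with an aromatic ring gives way to a small group without a ring.

Going by the values given here, no measured pair shows a change of this kind, so the expectation rests on compound 1 alone. For compound 3 the step of a 1.6-fold higher number from compound 1 to compound 3 (0.21 log units; within the scatter) is expected to be small, leaning toward weaker inhibition but possibly within the scatter. Compound 3 is therefore estimated at 70 nM, with a likely range from 20 nM to 250 nM.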

Compound 3, half-maximal inhibitory concentration: 63 nM
Estimate against measurement, compound 3: 1.1-fold (0.05 log units) above; the range from low to high includes it.
By their numbers in this assay, from the lowest: compounds 1 and 3 (each within the scatter of the next); then compound 2.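

In this assay, replacing the benzylcarbamoyl group with sulfamoyl gives a 1.5-fold higher number from compound 1 to compound 3 (0.17 log units; within the scatter), so the two compounds cannot be told apart on this measurement. Going by these compounds alone, this is the first look at how much this position allows: benzylcarbamoyl brings a six-membered aromatic ring and many more heavy atoms, while sulfamoyl has no ring and far fewer heavy atoms, yet the numbers stay within the scatter of each other. For this pair, then, the aromatic ring of benzylcarbamoyl is not required for inhibition at this level, although no measurement shown here explains the result.

One swap cannot show whether this tolerance belongs to small groups in general or to sulfamoyl in particular, and an acetyl group, a methyl group or a bare ring amine carrying only hydrogen could test that. On these data alone, it also remains open how far the group can grow or vary, for example with a longer chain on the sulfonyl or a carboxylic acid at its end.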